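Cytotoxicity of Two Analogues and an Expected Third

The source may hold more compounds than are shown below. What is called first, only, known or untested is meant among the compounds shown, and "the series" means these compounds.

Of the compounds shown here, two sharing one core have been tested in an ADME assay on MT4 cells (Homo sapiens) for cytotoxicity, read by MTT assay; on this read-out higher numbers stand for lower toxicity in this test and lower numbers for higher toxicity in this test. Among the compounds with values here, compound 1 `Cc1cc(C#N)cc(C)c1Oc1ccnc(Nc2ccc(CN3CCN(S(=O)(=O)N(C)C)CC3)cc2)n1` is the first of them; in this assay compound 1 gives 4460 nM. The second, compound 2 `Cc1cc(/C=C/C#N)cc(C)c1Oc1ccnc(Nc2ccc(CN3CCCN(S(=O)(=O)C(C)C)CC3)cc2)n1`, differs from it in more than one place; in this assay compound 2 gives 4640 nM. Compound 1 carries the lowest of the two numbers, but the gap to compound 2 lies within the usual scatter of such measurements, so the two values show no real separation between them.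

A third member, compound 3 `Cc1cc(C#N)cc(C)c1Oc1ccnc(Nc2ccc(CN3CCCN(S(C)(=O)=O)CC3)cc2)n1`, has not yet been measured. It differs from compound 1 by a single change at one place: 4-(methylsulfonyl)-1,4-diazepan-1-yl in place of 4-(dimethylsulfamoyl)piperazin-1-yl on a saturated chain carbon bound to an aromatic carbon. Within the data shown here, no measured pair in this set isolates that change, so nothing shows how this assay responds to it. With both measured compounds sitting close together, the step of a 1.0-fold higher number from compound 1 to compound 3 (0.00 log units; within the scatter) is expected to stay within the scatter, in no clear direction. On that basis compound 3 is estimated to give 4500 nM in this assay, with a range from 1800 nM to 11000 nM.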

Compound 3, half-maximal cytotoxic concentration: 7850 nM
Estimate against measurement, compound 3: 1.7-fold (0.24 log units) below; the range from low to high includes it.
By their numbers in this assay, from the lowest: compounds 1, 2 and 3 (each within the scatter of the next).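

Within the data shown here, the step at this position is the first that can be read for a single change: in this assay, 4-(methylsulfonyl)-1,4-diazepan-1-yl in place of 4-(dimethylsulfamoyl)piperazin-1-yl on a saturated chain carbon bound to an aromatic carbon gives a 1.8-fold higher number from compound 1 to compound 3 (0.25 log units; within the scatter). Among these compounds, this place on the shared core therefore takes the seven-membered ring with its methylsulfonyl group in place of the six-membered ring with its dimethylsulfamoyl group without any separation beyond the scatter, although the two groups differ in both ring size and sulfonyl substituent, and the single step cannot divide its size between those two differences. Nothing available bears on what lies behind this result.

The compounds shown leave open how a 4-(methylsulfonyl)piperazin-1-yl group would read at this place, a comparison that would separate the ring size from the group on the sulfonyl. They also leave open whether the numbers would stay this close with a group of another kind on the ring nitrogen, such as an acetyl group or a carboxylic acid on a short chain.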